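The compounds below may be only part of what the source reports. "The series", "measured", "known", "first", "only" and "open" are said of these compounds alone.

Working notes on the series. Among the measured compounds shown here, compound 2 `C/C=C/C(=O)Nc1c(C(O)(C(F)(F)F)C(F)(F)F)ccc2ccccc12` stands as the higher of the two numbers so far in an assay on LtK cells with ATP-sensitive inward rectifier potassium channel 11 (Homo sapiens) as the target (on this read-out higher numbers stand for an effect only at larger amounts of compound and lower numbers for an effect already at smaller amounts), where compound 2 gives 72 nM; compound 1 `CC(=O)Nc1c(C(O)(C(F)(F)F)C(F)(F)F)ccc2ccccc12` gives 18 nM. For the measured compounds named here, the only step on record, a 4.0-fold higher number from compound 1 to compound 2 (0.60 log units; beyond the scatter), accompanies a larger group on the carbonyl carbon. Compound 3 `CCCC(C)C(=O)Nc1c(C(O)(C(F)(F)F)C(F)(F)F)ccc2ccccc12` carries a further enlargement there: 1-methylbutyl in place of prop-1-en-1-yl on a carbonyl carbon. Going by the values given here, with only that one step as guidance, a further weakening of similar size is expected, though a saturated branched chain has no precedent here. The estimate for compound 3 is 150 nM in this assay, spanning 40 nM to 600 nM, an expected step of a 2.1-fold higher number from compound 2 to compound 3 (0.32 log units; beyond the scatter).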

Compound 3, half-maximal effective concentration: > 10000 nM
Compound 3: no number, only a limit (the forecaster's own chance of this, stated with the estimate: 5%); middle value at least 66-fold (1.82 log units) from the limit.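

Compound 3 gives a limit and not a number in this assay: the limit of > 10000 nM in this assay, at which 1 of the 3 values shown sits.

On the carbonyl carbon, 1-methylbutyl gives an at least 130-fold higher number from compound 2 to compound 3 (2.14 log units; beyond the scatter), and measured against methyl it gives an at least 550-fold higher number from compound 1 to compound 3 (2.74 log units; beyond the scatter). The carbonyl substituent therefore shows a far steeper loss than the modest step to prop-1-en-1-yl suggested, and larger groups here are not interchangeable.

The compounds shown do not separate chain length, branching and the loss of the double bond, since compound 3 differs from compound 2 in all three. An ethyl, an unbranched butyl or a cyclopropyl group on the carbonyl carbon would address this.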